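A few compounds are considered here, and "the series" means these few. Any claim that something is new, unique, unknown or untested is made for them only; others in the source may bear on it.

Measured so far:

Compound 1 `Nc1nc(O)c2c(n1)n(C1OC(CO)[C@@H](O)[C@H]1O)c(=O)n2Cc1ccc(Cl)c(Cl)c1` — 55%
Compound 2 `Nc1nc(O)c2c(n1)n(C1OC(CO)[C@@H](O)[C@H]1O)c(=O)n2CC(O)CO` — 136%
Compound 3 `CCn1c(=O)n(C2OC(CO)[C@@H](O)[C@H]2O)c2nc(N)nc(O)c21` — 82%

In a functional assay on the whole organism (B cells) with Mus musculus as the target (a higher number here means a larger maximal response, a lower number a smaller maximal response), compound 3 stands second highest of the three, above compound 1 by a number 27 percentage points higher from compound 1 to compound 3 (beyond the scatter) and below compound 2 by a number 54 percentage points lower from compound 2 to compound 3 (beyond the scatter). Compound 4 `Nc1nc(O)c2c(n1)n(C1OC(CO)[C@@H](O)[C@H]1O)c(=O)n2CCN1CCCCC1` differs from compound 3 by piperidin-1-yl in place of hydrogen on a saturated chain carbon, two bonds along the chain from an aromatic nitrogen. For the measured compounds named here, no measured step changes the same spot on the chain; the closest comparison is the large rise of a number 81 percentage points higher from compound 1 to compound 2 (beyond the scatter), where a group carrying acceptors replaced a group carrying none. That single case gives only a weak hint, so for compound 4 a step of a number 13 percentage points higher from compound 3 to compound 4 (beyond the scatter) in this assay is expected, roughly within the scatter. Compound 4 is therefore estimated at 95%, with a range from 60% to 130%.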

Compound 4, largest response reached (reported as maximal response), in percent of the reference or control that the assay uses: 0%
The estimate for compound 4 lay 95 percentage points above the measured number; the whole stated range lies above it.
By their numbers in this assay, from the lowest: compound 4; then compound 1; then compound 3; then compound 2.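

In this assay, the 2-(piperidin-1-yl)ethyl group gives the lowest number of the series, with a number 82 percentage points lower from compound 3 to compound 4 (beyond the scatter), a number 136 percentage points lower from compound 2 to compound 4 (beyond the scatter) and a number 55 percentage points lower from compound 1 to compound 4 (beyond the scatter). The earlier compounds shown here showed this position moving the response up or down, whereas here compound 4 gives 0%, so a change at this position can leave no response at all. No measurement shown here explains this drop. Going by these compounds, it remains open whether the result depends on the amine nitrogen or on the ring, a question that a 2-(dimethylamino)ethyl or 2-cyclohexylethyl group in the same place could help separate.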